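Butylamino in place of cyclopentylsulfanyl on a shared core

The compounds below may be only part of what the source reports. "The series", "measured", "known", "first", "only" and "open" are said of these compounds alone.

- Compound 1 `CC(C)Nc1nc(N)nc2c1ncn2/C=C1/CC1(CO)CO`: "not determined" (no result reported)
- Compound 2 `Nc1nc(SC2CCCC2)c2ncn(/C=C3/CC3(CO)CO)c2n1`: > 20000 nM

In an ADME assay on MOLT-3 cells (Homo sapiens) for cytotoxicity, with a stated time of 7 days (on this read-out lower numbers stand for higher toxicity in this test and higher numbers for lower toxicity in this test), compound 2 gives > 20000 nM, which is a limit of the assay and not a number. Among the measured compounds shown here, this limit is the only guide here, since compound 1 has no result. Compound 3 `CCCCNc1nc(N)nc2c1ncn2/C=C1/CC1(CO)CO` carries butylamino in place of cyclopentylsulfanyl on an aromatic carbon. For the measured compounds named here, no measured pair shows what this swap does, so no step beyond the usual scatter is expected in this assay, in either direction. The estimated change is a step that the limit leaves unreadable from compound 2 to compound 3. Compound 3 is expected at 25000 nM, within an estimated range of 8000 nM to 80000 nM.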

Compound 3, half-maximal cytotoxic concentration: > 20000 nM
Compound 3: a limit, no number; the forecaster's own chance of this, stated with the estimate: 70%; the middle value lies beyond the limit too.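

In this assay, no step can be read between compound 2 and compound 3, because both results are limits of the assay and not numbers: the limit of > 20000 nM in this assay, at which 2 of the 3 values shown sit.

The compounds shown leave open whether butylamino in place of cyclopentylsulfanyl changes the read-out at all.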